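Morpholin-4-yl in Place of Methyl on a Carbonyl Carbon

This account rests on a few compounds, and the source may have more. Where it says the series, first, only, none or still open, it means among the compounds named here.

Within the data shown here, in a functional assay on HEK239 cells (Homo sapiens) for inhibition, read by ELISA, with a stated time of 24 h (on this read-out higher numbers stand for weaker inhibition of growth and lower numbers for stronger inhibition of growth), compound 2 (`CC(=O)ONC(=O)/C=C/c1ccccc1OC(=O)c1ccccc1`) gives 18600 nM as the lower of the two numbers so far, while compound 1 (`CN1CCN(C(=O)ONC(=O)/C=C/c2ccccc2OC(=O)c2ccccc2)CC1`) gives 89300 nM in that read-out. Compound 3 (`O=C(/C=C/c1ccccc1OC(=O)c1ccccc1)NOC(=O)N1CCOCC1`) follows from compound 2 through morpholin-4-yl in place of methyl on a carbonyl carbon with morpholin-4-yl in place of methyl on a carbonyl carbon. Among the measured compounds shown here, the one measured step that bears on this is a 4.8-fold lower number from compound 1 to compound 2 (0.68 log units; beyond the scatter) on putting methyl in place of 4-methylpiperazin-1-yl. A step of similar size in the opposite direction, towards a higher number, is therefore expected in this assay. The expected change is a 3.2-fold higher number from compound 2 to compound 3 (0.51 log units; beyond the scatter) in this estimate. The estimated value for compound 3 is 60000 nM (range 20000 nM to 150000 nM).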

Compound 3, concentration for 50% growth inhibition: 5800 nM
The estimate for compound 3 lay 10-fold (1.01 log units) above the measured number; measured number below the stated range.
By their numbers in this assay, from the lowest: compound 3; then compound 2; then compound 1.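

On this carbonyl carbon, a six-membered ring group does not by itself raise the number: in this assay, morpholin-4-yl in place of methyl gives a 3.2-fold lower number from compound 2 to compound 3 (0.51 log units; beyond the scatter). Among these compounds, the two ring groups fall on opposite sides of methyl, and exchanging 4-methylpiperazin-1-yl for morpholin-4-yl gives the largest step so far, a 15-fold lower number from compound 1 to compound 3 (1.19 log units; beyond the scatter). Nothing available explains this difference between the two ring groups. As far as these compounds go, it remains open whether piperidin-1-yl or an open-chain dimethylamino group here would give a number nearer that of morpholin-4-yl or that of 4-methylpiperazin-1-yl.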